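The source may hold more compounds than are shown below. What is called first, only, known or untested is meant among the compounds shown, and "the series" means these compounds.

Of the compounds shown here, three have been measured in an assay on Huh-7 cells for agonist activity at Bile acid receptor (Homo sapiens), read by a luciferase reporter (a lower number here means that less compound is needed, a higher number that more compound is needed for the effect), and all of them share one core that differs only in the group sitting on an aromatic nitrogen. Compound 1 `CCn1c(-c2ccc(OCc3c(-c4c(Cl)cccc4Cl)noc3C(C)C)cc2)nc2ccc(C(=O)O)cc21` carries an ethyl group there and gives 2.31 nM. Compound 2 `CCCC(CCC)n1c(-c2ccc(OCc3c(-c4c(Cl)cccc4Cl)noc3C(C)C)cc2)nc2ccc(C(=O)O)cc21` carries a 1-propylbutyl group and gives 1.8 nM; the step of a 1.3-fold lower number from compound 1 to compound 2 (0.11 log units; within the scatter) lies within the scatter of the method. Compound 3 `CC(C)c1onc(-c2c(Cl)cccc2Cl)c1COc1ccc(-c2nc3ccc(C(=O)O)cc3n2-c2ccc(F)cc2)cc1` carries a 4-fluorophenyl group and gives 32.2 nM, the highest number of the three: it stands a 14-fold higher number from compound 1 to compound 3 (1.14 log units; beyond the scatter) and an 18-fold higher number from compound 2 to compound 3 (1.25 log units; beyond the scatter), both well beyond the scatter.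

Compound 4 `CC(C)c1onc(-c2c(Cl)cccc2Cl)c1COc1ccc(-c2nc3ccc(C(=O)O)cc3n2C(C)C)cc1` is the next step from compound 3: isopropyl in place of 4-fluorophenyl on an aromatic nitrogen. The group that enters is a short branched chain, and the measured steps speak to it directly. Both a 14-fold higher number from compound 1 to compound 3 (1.14 log units; beyond the scatter) and an 18-fold higher number from compound 2 to compound 3 (1.25 log units; beyond the scatter) show that putting the aromatic ring on this nitrogen raised the number sharply, while the comparison between two chains, a 1.3-fold lower number from compound 1 to compound 2 (0.11 log units; within the scatter), hardly mattered. Returning to a chain is therefore expected to undo most of that rise, a large step downward in the number, with the caution that isopropyl is not identical to either chain measured. For compound 4 the estimate in this assay is 2.5 nM, with a range from 1 nM to 8 nM, which corresponds to an expected step of a 13-fold lower number from compound 3 to compound 4 (1.11 log units; beyond the scatter).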

Compound 4, half-maximal effective concentration: 3.39 nM
The estimate for compound 4 lay 1.4-fold (0.13 log units) below the measured number, and the stated range covers the measured number.
By their numbers in this assay, from the lowest: compounds 2, 1 and 4 (each within the scatter of the next); then compound 3.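

In this assay, replacing 4-fluorophenyl with isopropyl on the aromatic nitrogen gives a 9.5-fold lower number from compound 3 to compound 4 (0.98 log units; beyond the scatter), which shows that the sharp rise seen with the aromatic ring also separates it from a short branched chain, not only from ethyl and 1-propylbutyl. Compound 4 also falls in with the other two chain compounds: the comparisons give a 1.5-fold higher number from compound 1 to compound 4 (0.17 log units; within the scatter) and a 1.9-fold higher number from compound 2 to compound 4 (0.27 log units; within the scatter), so ethyl, isopropyl and 1-propylbutyl cannot be told apart here, and among these four compounds only compound 3, with its ring, stands apart from this group. Nothing available explains the gap between the ring and the chains.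

The compounds shown leave open whether the difference follows the ring itself or its fluorine, a question that a plain phenyl and a saturated cyclohexyl on this nitrogen could help to separate. The three chains shown hold only carbon, so it also remains open how a chain ending in an amine or a hydroxyl group would behave at this position.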